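A few compounds are considered here, and "the series" means these few. Any claim that something is new, unique, unknown or untested is made for them only; others in the source may bear on it.

Measured compounds:
Compound 1, `N#CC1=C(N)Oc2c(N)cc3nc4ccccc4nc3c2C12C(=O)N(Cc1cnnn1-c1cccc(C(F)(F)F)c1)c1ccccc12`: in an ADME assay on L02 cells (Homo sapiens) for antiproliferative activity, read by MTT assay, with a stated time of 48 h (a lower number here means a stronger inhibitor, a higher number a weaker inhibitor), compound 1 gives 38100 nM.
Compound 2, `N#CC1=C(N)Oc2c(N)cc3nc4ccccc4nc3c2C12C(=O)N(Cc1cnnn1-c1ccc([N+](=O)[O-])cc1)c1ccccc12`: in this assay compound 2 reaches only the limit > 50000 nM.

Compound 2 therefore stands at the edge of what this assay reports, and only a bound is known for it; (the limit of > 50000 nM in this assay, at which 1 of the 2 values shown sits). Compound 3, `CCc1cccc(C)c1-n1nncc1CN1C(=O)C2(C(C#N)=C(N)Oc3c(N)cc4nc5ccccc5nc4c32)c2ccccc21`, differs from compound 2 by 2-ethyl-6-methylphenyl in place of 4-nitrophenyl on an aromatic nitrogen. Going by the values given here, the only measured step that touches the same aromatic nitrogen, an at least 1.3-fold higher number from compound 1 to compound 2 (0.11 log units; that floor lies within the scatter), shifted the number by no more than the scatter and ended at a limit. The two values give no sign that exchanging one phenyl group for another there changes the number much, so in this assay only a small step is expected, an at least 1.1-fold lower number from compound 2 to compound 3 (0.04 log units; that floor lies within the scatter). Compound 3 is accordingly estimated at 45000 nM in this assay, with a range from 18000 nM to 110000 nM, and a limit rather than a number is about as likely as not.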

Compound 3, half-maximal inhibitory concentration: > 50000 nM
Compound 3 was reported as a limit; the forecaster's own chance of this, stated with the estimate: 50%; middle value at least 1.1-fold (0.04 log units) away from the limit.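

In this assay compound 3 also reaches only a limit, > 50000 nM, so a phenyl group with only carbon attached, 2-ethyl-6-methylphenyl, ends at the same edge as 4-nitrophenyl. The step between the two limits cannot be read, while 2-ethyl-6-methylphenyl in place of 3-(trifluoromethyl)phenyl gives an at least 1.3-fold higher number from compound 1 to compound 3 (0.11 log units; that floor lies within the scatter), so no change beyond the scatter is shown for this position. With a third aryl group on this aromatic nitrogen, the readings gather at one edge of what the assay reports: the limit of > 50000 nM in this assay, at which 2 of the 3 values shown sit.

As far as these compounds go, how far compound 2 and compound 3 lie past that limit stays open. So does whether a different group on this nitrogen, such as a phenyl bearing an amine or a carboxylic acid, or a plain alkyl chain, would give a clearly lower number.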